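Urea in place of benzyl at the ring nitrogen

The compounds below may be only part of what the source reports. "The series", "measured", "known", "first", "only" and "open" are said of these compounds alone.

Measured so far in a functional assay on MKN-74 cells (Homo sapiens) for antiproliferative activity, with a stated time of 24 h; on this read-out higher numbers stand for weaker inhibition and lower numbers for stronger inhibition:
compound 1 `NC(=O)c1c(NC(=O)c2ccccc2Cl)sc2c1CCN(Cc1ccccc1Cl)C2` gives 4430 nM
compound 2 `NC(=O)c1c(NC(=O)c2ccccc2Cl)sc2c1CCN(Cc1ccc(Cl)cc1)C2` gives 18700 nM
compound 3 `NC(=O)c1c(NC(=O)c2ccccc2Cl)sc2c1CCN(Cc1ccc(Cl)cc1Cl)C2` gives 16300 nM

Compound 3 gives the second highest of the three numbers in this assay; its nearest neighbour is compound 2, and the step of a 1.1-fold lower number from compound 2 to compound 3 (0.06 log units; within the scatter) lies within the scatter, while a 3.7-fold higher number from compound 1 to compound 3 (0.57 log units; beyond the scatter) and a 4.2-fold higher number from compound 1 to compound 2 (0.63 log units; beyond the scatter) lie beyond it. Compound 4 `NC(=O)c1c(NC(=O)c2ccccc2Cl)sc2c1CCN(C(=O)Nc1ccccc1Cl)C2` differs from compound 3 by (2-chlorophenyl)carbamoyl in place of 2,4-dichlorobenzyl on an amine nitrogen in a ring. Going by the values given here, none of the measured steps changes the group at this nitrogen beyond the placing of chloro on the benzyl, so no step bears directly on this change. Compound 4 is therefore expected near compound 3, with a step of a 2.0-fold lower number from compound 3 to compound 4 (0.31 log units; beyond the scatter) in this assay, leaning toward a lower number because compound 1 with its 2-chlorophenyl gives 4430 nM. The estimate for compound 4 is 8000 nM, between 2500 nM and 25000 nM.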

Compound 4, half-maximal inhibitory concentration: 16300 nM
Compound 4: middle estimate off by 2.0-fold (0.31 log units), on the low side, and the stated range covers the measured number.
By their numbers in this assay, from the lowest: compound 1; then compounds 3, 4 and 2 (each within the scatter of the next).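

In this assay the step of no change at the digits printed from compound 3 to compound 4 (within the scatter) and the step of a 1.1-fold lower number from compound 2 to compound 4 (0.06 log units; within the scatter) show that (2-chlorophenyl)carbamoyl on this amine nitrogen reads like 2,4-dichlorobenzyl and 4-chlorobenzyl. The step of a 3.7-fold higher number from compound 1 to compound 4 (0.57 log units; beyond the scatter) shows that a 2-chlorophenyl carried on the carbamoyl does not reproduce the lower number given by 2-chlorobenzyl. Nothing reported here gives a reason for this result. The compounds shown leave open how a carbamoyl with a plain phenyl or a 4-chlorophenyl would read at this nitrogen. They also leave open how a sulfonyl or acetyl group would read there.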